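The compounds below may be only part of what the source reports. "The series", "measured", "known", "first", "only" and "open" are said of these compounds alone.

Measured compounds:
- compound 1, `C[C@@H](O[C@H]1CN(C(=O)OC(C)(C)C)[C@@H](CO)[C@@H]1c1ccc(F)cc1)c1cc(C(F)(F)F)cc(C(F)(F)F)c1`: 0.28 nM
- compound 2, `C[C@@H](O[C@H]1CN2C(=O)N(C)C[C@H]2[C@@H]1c1ccc(F)cc1)c1cc(C(F)(F)F)cc(C(F)(F)F)c1`: 0.88 nM
- compound 3, `C[C@@H](O[C@H]1CN2C(=O)NC[C@H]2[C@@H]1c1ccc(F)cc1)c1cc(C(F)(F)F)cc(C(F)(F)F)c1`: 0.06 nM

In an assay on CHO cells for displacement of a labelled ligand from Substance-P receptor (Homo sapiens) (on this read-out higher numbers stand for weaker inhibition and lower numbers for stronger inhibition), compound 3 gives the lowest number of the three; compound 1 sits nearest, compound 2 furthest, with both gaps beyond the scatter.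

Compound 4, `C[C@@H](O[C@H]1CN2C(=O)N(Cc3ccccc3)C[C@H]2[C@@H]1c1ccc(F)cc1)c1cc(C(F)(F)F)cc(C(F)(F)F)c1`, has not yet been measured. It differs from compound 3 by benzyl in place of hydrogen on an amide-type nitrogen in a ring.

Among the measured compounds shown here, one measured step bears on this change: a 15-fold lower number from compound 2 to compound 3 (1.17 log units; beyond the scatter), where removal of the methyl from that ring nitrogen lowered the number sharply. For the measured compounds named here, compound 4 instead places a benzyl on the same nitrogen, so the single relevant step points toward a higher number than compound 3, and a substituent of seven heavy atoms gives no basis to expect a smaller effect than the methyl did. Going by the values given here, no measured compound carries a benzyl at this position, so the size of the step is uncertain.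

Compound 4 is therefore expected to give 1.5 nM in this assay, within 0.3 nM to 8 nM, the step of a 25-fold higher number from compound 3 to compound 4 (1.40 log units; beyond the scatter) being an estimate.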

Compound 4, half-maximal inhibitory concentration: 2.7 nM
The estimate for compound 4 lay 1.8-fold (0.26 log units) below the measured number; the range from low to high includes it.
By their numbers in this assay, from the lowest: compound 3; then compound 1; then compound 2; then compound 4.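

In this assay, a benzyl on this amide-type nitrogen gives a 45-fold higher number from compound 3 to compound 4 (1.65 log units; beyond the scatter), so the sensitivity seen with methyl also holds for a group carrying an aromatic ring. Lengthening methyl to benzyl adds a 3.1-fold higher number from compound 2 to compound 4 (0.49 log units; beyond the scatter), a modest step that is still beyond the scatter, so across compound 3, compound 2 and compound 4 the number rises in the order hydrogen, methyl, benzyl. Nothing measured here accounts for this order.

Among the compounds shown here, these three substituents fix no trend beyond these compounds, and whether an ethyl or a longer alkyl chain on this nitrogen would fall between methyl and benzyl stays open. Also open, going by these compounds, is how a benzyl carrying an amine or a carboxylic acid on its phenyl ring would read at this position.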